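This account rests on a few compounds, and the source may have more. Where it says the series, first, only, none or still open, it means among the compounds named here.

In an ADME assay on microsomes from liver (Mus musculus) for metabolic stability, with a stated time of 10 min (on this read-out higher numbers stand for a more stable compound and lower numbers for a less stable compound), two compounds have been measured so far. Compound 1 (`C[C@]1(C(=O)N2CC[C@](c3ccc(C(F)(C(F)(F)F)C(F)(F)F)cc3)(S(=O)(=O)c3ccc(F)cc3)C2)CC[C@H](C(=O)O)CC1`) gives 95%, and compound 2 (`CCC1(C(=O)N2CC[C@](c3ccc(C(F)(C(F)(F)F)C(F)(F)F)cc3)(S(=O)(=O)c3ccc(F)cc3)C2)CCS(=O)(=O)CC1`) gives 0%, the lower of the two numbers. Compound 3 (`O=C(N1CC[C@](c2ccc(C(F)(C(F)(F)F)C(F)(F)F)cc2)(S(=O)(=O)c2ccc(F)cc2)C1)C1(O)CCS(=O)(=O)CC1`) has not yet been measured. Its structure differs from that of compound 2 in one place: hydroxy in place of ethyl on a saturated ring carbon. In words, hydroxy stands in place of ethyl on a saturated ring carbon, three ring bonds from the ring sulfur, which turns 4-ethyl-1,1-dioxothian-4-yl into 4-hydroxy-1,1-dioxothian-4-yl.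

For the measured compounds named here, only one measured step bears on this change, and only loosely. That step is a number 95 percentage points lower from compound 1 to compound 2 (beyond the scatter), and it too involved 4-ethyl-1,1-dioxothian-4-yl. Going by the values given here, it shows that this read-out can move over a large span, but no measured step swaps ethyl for hydroxy. A change beyond the scatter can only be upward, since compound 2 gives 0%. The expected step, held with little certainty, is a number 30 percentage points higher from compound 2 to compound 3 (beyond the scatter). For compound 3 the estimated value is 30%, with an expected range from 5% to 70%.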

Compound 3, percent of the compound remaining: 90%
Beside the measured number, compound 3's estimate is 60 percentage points below it, and the stated range ends below it.
By their numbers in this assay, from the lowest: compound 2; then compounds 3 and 1 (each within the scatter of the next).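

In this assay, the change of hydroxy in place of ethyl on a saturated ring carbon, three ring bonds from the ring sulfur, goes with a number 90 percentage points higher from compound 2 to compound 3 (beyond the scatter), so this single position can carry the read-out across nearly its whole span. The earlier step exchanged the entire group on the carbonyl carbon, whereas the new comparison with a number 5 percentage points lower from compound 1 to compound 3 (within the scatter) shows that 4-hydroxy-1,1-dioxothian-4-yl and 4-carboxy-1-methylcyclohexyl stand level here, so the sulfur-containing ring does not by itself go with a low number. Nothing available explains why the ethyl and hydroxy compounds part so widely.

The compounds shown leave open whether a methyl group, a methoxy group, an amine or a fluorine atom on this ring carbon would fall with compound 2 or with compound 3. They also leave open whether the exchange of ethyl for hydroxy would have a step of similar size on a plain cyclohexyl ring without the ring sulfur.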